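Closing the amino chain of compound 3 into a ring

The source may hold more compounds than are shown below. What is called first, only, known or untested is meant among the compounds shown, and "the series" means these compounds.

Of the compounds shown here, three sharing one core have been measured in a functional assay on SW480 cells (Homo sapiens) for inhibition; on this read-out higher numbers stand for weaker inhibition and lower numbers for stronger inhibition. Compound 1 `CCN[C@H](C#Cc1c(F)ccc2c1/C(=C/c1[nH]ccc1OC)C(=O)N2)CO` gives 566 nM, and compound 2 `COc1cc[nH]c1/C=C1\C(=O)Nc2ccc(F)c(C#C[C@H](CO)NCCO)c21` gives 967 nM; the step between them is a 1.7-fold higher number from compound 1 to compound 2 (0.23 log units; within the scatter). Compound 3 `COc1cc[nH]c1/C=C1\C(=O)Nc2ccc(F)c(C#C[C@@H](N)[C@@H](C)O)c21` gives 210 nM, the lowest number and so the strongest inhibition of the three.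

Compound 4 `COc1cc[nH]c1/C=C1\C(=O)Nc2ccc(F)c(C#C[C@@H]3C[C@H](O)CN3)c21` has not yet been measured. Its change lies on a triple-bonded carbon: 4-hydroxypyrrolidin-2-yl in place of 1-amino-2-hydroxypropyl on a triple-bonded carbon. In short, 4-hydroxypyrrolidin-2-yl stands in place of 1-amino-2-hydroxypropyl.

For the measured compounds named here, no measured step makes this exact change, so the nearest guides are the two steps that also swap the group at this place. They are a 2.7-fold lower number from compound 1 to compound 3 (0.43 log units; beyond the scatter) and a 4.6-fold lower number from compound 2 to compound 3 (0.66 log units; beyond the scatter), both modest. In compound 1 and compound 2 the amine nitrogen carries a further carbon group, and in compound 4 it also carries a further carbon, as part of the ring. On that likeness, a number somewhat higher than that of compound 3 is expected, though probably less of a move than those two steps. The expected step in this assay is a 1.6-fold higher number from compound 3 to compound 4 (0.21 log units; within the scatter). For compound 4 the estimated value is 340 nM, with an expected range from 110 nM to 1000 nM.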

Compound 4, half-maximal inhibitory concentration: 90 nM
For compound 4 the middle estimate is 3.8-fold (0.58 log units) above the measured one; measured number below the stated range.
By their numbers in this assay, from the lowest: compound 4; then compound 3; then compounds 1 and 2 (each within the scatter of the next).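

In this assay, tying the open 1-amino-2-hydroxypropyl chain into the 4-hydroxypyrrolidin-2-yl ring gives a 2.3-fold lower number from compound 3 to compound 4 (0.37 log units; beyond the scatter) and so shows that this place on the triple-bonded carbon can take a ring, with no loss and in fact a lower number. The ring's nitrogen carries a further carbon, as do the nitrogens of the open chains in compound 1 and compound 2, yet those two compounds have higher numbers than compound 3 while the ring compound has a lower one, so a further carbon on this nitrogen does not by itself go with weaker inhibition. For the compounds shown here, the gap to those open chains is wide, at a 6.3-fold lower number from compound 1 to compound 4 (0.80 log units; beyond the scatter) and an 11-fold lower number from compound 2 to compound 4 (1.03 log units; beyond the scatter), the second being the only large step at this place; nothing in the available data explains why the ring goes with stronger inhibition.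

Going by these compounds, whether the hydroxy on the ring matters remains open, a question that a plain pyrrolidin-2-yl group would answer. Also open, on these data alone, is how a larger piperidin-2-yl ring, a methyl group on the ring nitrogen or the opposite arrangement at the two stereocentres would compare.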